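Chain length between a thiophene-free core and a phenyl ring

The compounds below may be only part of what the source reports. "The series", "measured", "known", "first", "only" and "open" are said of these compounds alone.

Measured so far:
- compound 1, `Cc1ccc(-c2nc(N)c3cc(-c4ccccc4)sc3n2)o1`: 520 nM
- compound 2, `Cc1ccc(-c2nc(N)c3cc(Cc4ccccc4)sc3n2)o1`: 298 nM

In a functional assay on CHO-K1 cells for antagonist activity at adenosine receptor A1 (Homo sapiens), read by a beta-galactosidase reporter and cAMP accumulation, with stated times of 15 min and 6 h (a lower number here means a stronger inhibitor, a higher number a weaker inhibitor), compound 2 gives the lowest of the two numbers; its nearest neighbour is compound 1, and the difference, a 1.7-fold lower number from compound 1 to compound 2 (0.24 log units; within the scatter), is within the scatter, so the two cannot be ranked against each other.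

Compound 3, `Cc1ccc(-c2nc(N)c3cc(CCc4ccccc4)sc3n2)o1`, carries the same change one bond further out: benzyl in place of phenyl on a saturated chain carbon bound to an aromatic carbon. Among the compounds with values here, the only measured step that bears on this kind of lengthening is the one from compound 1 to compound 2, which was too small to count. Nothing in the data suggests that one more link in the chain would move the number beyond the scatter in either direction.

Compound 3 is therefore estimated at 320 nM in this assay, with a likely range from 110 nM to 950 nM. The expected step from compound 2 to compound 3 is a 1.1-fold higher number from compound 2 to compound 3 (0.03 log units; within the scatter), which is no change beyond the scatter.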

Compound 3, inhibition constant: 2780 nM
Estimate against measurement, compound 3: 8.7-fold (0.94 log units) below; the measured number lies above the stated range.
By their numbers in this assay, from the lowest: compounds 2 and 1 (each within the scatter of the next); then compound 3.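

Lengthening the link from benzyl to phenethyl gives a 9.3-fold higher number from compound 2 to compound 3 (0.97 log units; beyond the scatter) in this assay, whereas the step from phenyl to benzyl stayed within the scatter, so this position does respond to the length of the chain. Set against the directly attached phenyl, phenethyl also gives a 5.3-fold higher number from compound 1 to compound 3 (0.73 log units; beyond the scatter), which means the two shorter groups stay level and the change appears only at the phenethyl chain, not gradually with each added carbon. Nothing measured here explains why one more chain carbon has this effect.

The compounds shown leave open whether a longer chain, such as phenylpropyl, would raise the number further or level off. They also leave open what an amine in the chain or a methoxy group on the end phenyl ring would do.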